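Working notes: replacing the amine group of compound 1

The source may hold more compounds than are shown below. What is called first, only, known or untested is meant among the compounds shown, and "the series" means these compounds.

In an ADME assay on HCT-116 cells (Homo sapiens) for cytotoxicity, read by CellTiter-Glo, with a stated time of 72 h (on this read-out higher numbers stand for weaker inhibition and lower numbers for stronger inhibition), compound 1 (`Cc1cc(C)c(S(=O)(=O)N2CCN(C3CN4CCC3CC4)CC2)c(C)c1`) gives > 5000 nM as a limit of the assay, not a number. Compound 2 (`CC1CCN(C2CCN(S(=O)(=O)c3cn(C)c(=O)n(C)c3=O)CC2)CC1`) gives > 10000 nM in this assay as a limit too. For the measured compounds named here, compound 1 therefore stands at a limit, and the only other result is also a limit, so no measured step is available.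

Compound 3 (`Cc1cc(C)c(S(=O)(=O)N2CCN(C3CCN(C)CC3)CC2)c(C)c1`) differs from compound 1 at one place, where 1-methylpiperidin-4-yl enters (a group of 7 heavy atoms (6 carbon, 1 nitrogen; one six-membered non-aromatic ring with 1 hetero atom) in place of a group of 8 heavy atoms (7 carbon, 1 nitrogen; 2 six-membered non-aromatic rings with 1 hetero atom each), on an amine nitrogen in a ring) and the group of compound 1 at that place leaves.

Going by the values given here, with no measured step to draw on, the expectation in this assay is no step beyond the scatter in either direction. The closest reference is compound 1, which reads > 5000 nM as a limit and shares everything but the changed group. The estimated move a step that the limit leaves unreadable from compound 1 to compound 3 is expected to stay inside the scatter. Compound 3 is estimated at 8000 nM with an expected range of 3000 nM to 20000 nM and is likely to be reported as a limit again.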

Compound 3, half-maximal inhibitory concentration: > 5000 nM
Compound 3: only a limit was reported; the forecaster's own chance of this, stated with the estimate: 85%; the middle value lies beyond the limit too.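

Compound 3 reads only as a limit of the assay, as does compound 1, so no step between compound 1 and compound 3 can be read: the limit of > 5000 nM in this assay, at which 2 of the 3 values shown sit.

The compounds shown leave open whether any replacement of the amine group brings the read-out to a measured number, and how far apart compound 1 and compound 3 truly lie.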